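The source may report more compounds than this note shows. Statements on the series, on what has been measured and on what is new or still open speak of the compounds shown alone.

In a functional assay on MDA-MB-231 cells (Homo sapiens) for antiproliferative activity, read by sulforhodamine B assay, with a stated time of 48 h (a lower number here means a stronger inhibitor, a higher number a weaker inhibitor), compound 1 `COc1cc(C(=O)/C=C\Nc2ccc(-c3nc4cc(OC)c(OC)c(OC)c4s3)cc2C)cc([N+](=O)[O-])c1OC` gives 12800 nM, and compound 2 `COc1cc(C(=O)/C=C\Nc2ccc(-c3nc4cc(OC)c(OC)c(OC)c4s3)cc2)cc([N+](=O)[O-])c1OC` gives 9800 nM. Within the data shown here, these two values lie within the scatter of each other, so compound 1 does not stand apart from its only measured neighbour. The next compound to consider is compound 3 `COc1cc(C(=O)/C=C\Nc2ccc(-c3nc4cc(OC)c(OC)c(OC)c4s3)cc2C)cc(OC)c1OC`, which keeps the core of compound 1 but carries methoxy in place of nitro on an aromatic carbon. Among the measured compounds shown here, the only measured step is a 1.3-fold lower number from compound 1 to compound 2 (0.12 log units; within the scatter). It swaps a methyl for a hydrogen and leaves the nitro group untouched, so it says little about the new change beyond showing that one small edit to this scaffold left the number within the scatter. For the measured compounds named here, no measured pair tests a change at the nitro group, so both size and direction remain open. A cautious guess is a modest move towards a lower number, and the expected step is a 2.1-fold lower number from compound 1 to compound 3 (0.33 log units; beyond the scatter), though no change beyond the scatter would be equally unsurprising. For compound 3, the estimated value is 6000 nM, with an expected range from 800 nM to 20000 nM.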

Compound 3, half-maximal inhibitory concentration: 12900 nM
Estimate against measurement, compound 3: 2.2-fold (0.33 log units) below; the measured number falls inside the stated range.
By their numbers in this assay, from the lowest: compounds 2, 1 and 3 (each within the scatter of the next).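

In this assay, among these compounds, methoxy in place of nitro gives a 1.0-fold higher number from compound 1 to compound 3 (0.00 log units; within the scatter), which is the first direct test of this position, on the aromatic carbon ortho to a methoxy group; the earlier step concerned a methyl elsewhere in the molecule and left the nitro group in place. By the computed counts, the two groups are not the same: nitro has 3 heavy atoms and 2 hydrogen-bond acceptors, while methoxy has 2 heavy atoms and 1 hydrogen-bond acceptor, yet this exchange leaves the two numbers within the scatter of each other. No measurement available here offers an explanation for that result.

On these data alone, whether a different group at this position, such as an amine or a carboxylic acid, would give a step beyond the scatter remains open, since one exchange cannot show how the position responds to groups in general. As far as these compounds go, it is also open whether the same exchange would read alike on compound 2, which has hydrogen in place of the methyl.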